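Halogen exchange on the terminal phenyl ring

A few compounds are considered here, and "the series" means these few. Any claim that something is new, unique, unknown or untested is made for them only; others in the source may bear on it.

Three compounds of this series have numbers in a functional assay on A549 cells (Homo sapiens) for inhibition, read by sulforhodamine B assay, with a stated time of 48 h; a lower number here means a stronger inhibitor of growth, a higher number a weaker inhibitor of growth. Compound 1 `N=C(N)c1ccc(-c2ccc(-c3cc(Cl)cc(Cl)c3)s2)s1` gives 2070 nM. Compound 2 `N=C(N)c1ccc(-c2ccc(-c3ccc(Cl)cc3)s2)s1` gives 2110 nM in this assay. Compound 3 `COc1cc(OC)cc(-c2ccc(-c3ccc(C(=N)N)o3)o2)c1`, built on a different core and carrying two methoxy groups, gives 3780 nM in this assay. Compound 2 stands second highest of the three; its nearest neighbour is compound 1 and its furthest is compound 3, and both gaps lie within the scatter, so the three numbers cannot be put into an order.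

Compound 4 `N=C(N)c1ccc(-c2ccc(-c3ccc(F)cc3)s2)s1` has not yet been measured in this assay. Against compound 2 the change is fluoro in place of chloro on an aromatic carbon. Going by the values given here, no step between measured compounds covers this exchange, so no direction can be read from the numbers at hand. The step of a 1.3-fold higher number from compound 2 to compound 4 (0.12 log units; within the scatter) expected here is small and should stay within the scatter. Compound 4 is expected to give about 2800 nM in this assay, with a range from 1200 nM to 6500 nM.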

Compound 4, concentration for 50% growth inhibition: 1930 nM
For compound 4 the middle estimate is 1.5-fold (0.16 log units) above the measured one; low and high end bracket the measured number.
By their numbers in this assay, from the lowest: compounds 4, 1, 2 and 3 (each within the scatter of the next).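

In this assay, going by these compounds alone, fluoro in place of chloro on an aromatic carbon, para to a large group, gives a 1.1-fold lower number from compound 2 to compound 4 (0.04 log units; within the scatter) and so supplies the first step between compounds that differ in one place. At this position, the exchange of one halogen for the other produces no change that can be separated from the scatter, so compound 2 and compound 4 count as equal in this read-out. No measured data on either group or on this step are at hand to explain that result.

On this core, the compounds shown carry only halogens on the terminal phenyl ring, so the outcome with an amine or a carboxylic acid at this place remains open. Whether the same exchange would also leave the number unchanged on the core of compound 3 is open too.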